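Nitro to pentafluorosulfanyl on the anilino ring

The source may report more compounds than this note shows. Statements on the series, on what has been measured and on what is new or still open speak of the compounds shown alone.

Compound 1 `Oc1noc2cccc(Nc3cccc(C(F)(F)F)c3)c12`: 13%
Compound 2 `O=[N+]([O-])c1cccc(Nc2cccc3onc(O)c23)c1`: 0.37%

In an ADME assay on isolated protein for inhibition of cytochrome c oxidase subunit 2 (Homo sapiens), read by ELISA, tested at 100 uM (a lower number here means less inhibition, a higher number more inhibition at the concentration tested (going by the name of the read-out)), compound 2 gives 0.37%, the lowest of the two numbers; compound 1 gives 13%, and the step of a number 12.6 percentage points lower from compound 1 to compound 2 (beyond the scatter) is the only one measured. Compound 3 `Oc1noc2cccc(Nc3cccc(S(F)(F)(F)(F)F)c3)c12` differs from compound 2 by a group of 6 heavy atoms (5 fluorine, 1 sulfur; no ring) in place of a group of 3 heavy atoms (1 nitrogen, 2 oxygen; no ring), on an aromatic carbon. The change undoes the nitro and puts in a group of fluorine and sulfur, so the step of a number 12.6 percentage points lower from compound 1 to compound 2 (beyond the scatter) bears on it and a return of roughly that size is expected. Compound 3 is therefore estimated at 11%, within 0% to 28%, an expected step of a number 10.6 percentage points higher from compound 2 to compound 3 (beyond the scatter).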

Compound 3, a percentage reported as inhibition, at one concentration (the size of the read-out at that concentration, not a potency): 4.3%
The estimate for compound 3 lay 6.7 percentage points above the measured number, and the stated range covers the measured number.
By their numbers in this assay, from the lowest: compounds 2, 3 and 1 (each within the scatter of the next, the first and the last beyond it).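

In this assay, the group of 6 heavy atoms (5 fluorine, 1 sulfur) cannot be told apart from either group it replaces at this aromatic carbon: a number 3.9 percentage points higher from compound 2 to compound 3 (within the scatter) and a number 8.7 percentage points lower from compound 1 to compound 3 (within the scatter) both stay within the scatter. Only the gap between nitro and trifluoromethyl lies beyond it, so compound 3 adds no separate level to the series. No evidence is available that bears on this result.

On these data alone, whether an amine, a carboxylic acid or a methoxy group here would read like these three remains open.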